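This account rests on a few compounds, and the source may have more. Where it says the series, first, only, none or still open, it means among the compounds named here.

Measured compounds:
- compound 1 `Cc1ccc(S(=O)(=O)NCc2ccc(CNC(=O)c3ccc(F)cc3)cc2)cc1` — 75%
- compound 2 `COc1ccccc1C(=O)NCc1ccc(CNS(=O)(=O)c2ccccc2)cc1` — "not active" (no number reported)

Two compounds of this series have been run in a functional assay on the whole organism for inhibition, with Mus musculus as the target, with stated times of 30 min and 2 h, at a dose of 10 mg/kg by the intraperitoneal route; a higher number here means more inhibition at the dose given (going by the name of the read-out), a lower number less inhibition. Among the compounds with values here, compound 1 gives 75% and is the only entry with a number. Compound 2 is reported as "not active" (no number reported) with no figure attached. Within the data shown here, the two differ in more than one place, so no single step between them can be drawn; the values show only that compound 1 carries the one measured inhibition while compound 2 does not reach a reportable one.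

The next entry is compound 3 `Cc1ccc(S(=O)(=O)NCc2ccc(CNC(=O)c3ccc(Cl)cc3)cc2)cc1`, which differs from compound 1 in a single place: chloro in place of fluoro on an aromatic carbon. Among the measured compounds shown here, no step between measured compounds is available to gauge such a change. The swap of fluoro for chloro at this position is expected to produce no step beyond the usual scatter, in either direction. Compound 3 is therefore estimated at 75% in this assay , with a range from 55% to 90%. This estimate means an expected step of no change at the digits printed from compound 1 to compound 3 (within the scatter).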

Compound 3, a percentage reported as inhibition, in the whole organism at one dose (the size of the read-out at that dose, not a potency): 50%
Estimate against measurement, compound 3: 25 percentage points above, outside the stated range (below it).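

In this assay, the change from 4-fluorophenyl to 4-chlorophenyl gives a number 25 percentage points lower from compound 1 to compound 3 (beyond the scatter), so this position does not treat the two halogens alike. Within the data shown here, this is the first single-place step: one heavy atom is exchanged, with no change in ring, net charge or hydrogen-bond donors and acceptors, and that alone moves the read-out beyond the scatter, while compound 3 still shows a measurable inhibition of 50% at the dose given. No measurement at hand bears on why this step arises.

From the compounds shown here alone, with only fluoro and chloro at this position, the series gives a single step and no trend, so it remains open where a bromo, a nitrile, an amine or a carboxylic acid on the same aromatic carbon would fall relative to compound 1 and compound 3. Steps involving compound 2 cannot be read, so it also remains open whether the other aromatic ring of the core, which carries a methyl group in compound 1 and compound 3, contributes to the inhibition seen.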